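The compounds below may be only part of what the source reports. "The series", "measured", "known", "first", "only" and "open" are said of these compounds alone.

Working notes on the series, read in an ADME assay on the whole organism (Mus musculus, strain CD-1) for pharmacokinetics, at a dose of 10 mg/kg by the oral route; on this read-out lower numbers stand for lower oral bioavailability and higher numbers for higher oral bioavailability. Compound 1 (`COc1cc([C@](O)(CCN(C)C)[C@@H](c2cc3cc(Br)ccc3nc2OC)c2cccc(OC)c2F)cc(OC(C)C)n1`) gives 43% and compound 2 (`COc1cc([C@](O)(CCN(C)C)[C@@H](c2cc3cc(Br)ccc3nc2OC)c2ccnc(OC)c2OC)cc(OC(C)C)n1`) gives 22%, so compound 2 holds the lower of the two numbers. Compound 3 (`COc1nc2ccc(Br)cc2cc1[C@@H](c1ccnc(OC)c1OC)[C@@](O)(CCN(C)C)c1cc(SC)nc(SC)c1`) differs from compound 2 by a group of 10 heavy atoms (7 carbon, 1 nitrogen, 2 sulfur; one six-membered aromatic ring with 1 hetero atom) in place of a group of 12 heavy atoms (9 carbon, 1 nitrogen, 2 oxygen; one six-membered aromatic ring with 1 hetero atom), on a saturated chain carbon bound to an oxygen on a saturated carbon and two saturated chain carbons. Within the data shown here, the only measured step, a number 21 percentage points lower from compound 1 to compound 2 (beyond the scatter), is modest and lies at another place in the structure, so it gives a rough size but no direction. Among the measured compounds shown here, no measured step covers this change. The expected change is small, a number 3 percentage points higher from compound 2 to compound 3 (within the scatter). Compound 3 is expected at 25%, with an estimated range of 10% to 45%.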

Compound 3, oral bioavailability: 41%
For compound 3 the middle estimate is 16 percentage points below the measured one, and the stated range covers the measured number.
By their numbers in this assay, from the lowest: compound 2; then compounds 3 and 1 (each within the scatter of the next).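

In this assay, the saturated chain carbon bound to an oxygen on a saturated carbon and two saturated chain carbons now shows a measured effect: the group of 10 heavy atoms with 2 sulfur, in place of the group of 12 heavy atoms with 2 oxygen, gives a number 19 percentage points higher from compound 2 to compound 3 (beyond the scatter). Both groups have the same hydrogen-bond donor and acceptor counts, so those counts do not separate them. No measurement at hand gives a reason for this step. On these data alone, whether the step holds with 2-fluoro-3-methoxyphenyl in place of 2,3-dimethoxypyridin-4-yl stays open. Also open, as far as these compounds go, is how an amine or a trifluoromethyl on the ring at this place would read.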